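The compounds below may be only part of what the source reports. "The series", "measured", "known", "first", "only" and "open" are said of these compounds alone.

Compound 1, `COc1ncnc2c1c(I)cn2[C@@H]1O[C@H](CO)[C@@H](O)[C@H]1O`, in a functional assay on HCT-116 cells (Homo sapiens), read by MTT assay, with a stated time of 72 h (a higher number here means a weaker inhibitor, a lower number a stronger inhibitor), gives the limit > 20000 nM.
Compound 2, `C#Cc1cn([C@@H]2O[C@H](CO)[C@@H](O)[C@H]2O)c2ncnc(OC)c12`, in this assay gives 5140 nM.
Compound 3, `O=c1[nH]cnc2c1c(-c1cc3ccccc3o1)cn2[C@@H]1O[C@H](CO)[C@@H](O)[C@H]1O`, in this assay gives the limit > 20000 nM.

Compound 3 thus stands at the edge of what this assay can report: its value is a limit, not a number, and it sits at the limit of > 20000 nM in this assay, at which 2 of the 3 values shown sit. Compound 4, `O=c1[nH]cnc2c1c(-c1cccs1)cn2[C@@H]1O[C@H](CO)[C@@H](O)[C@H]1O`, differs from compound 3 in one place: thiophen-2-yl in place of 1-benzofuran-2-yl on an aromatic carbon. Among the compounds with values here, the one measured step, an at least 3.8-fold lower number from compound 1 to compound 2 (0.59 log units; beyond the scatter), concerns a different exchange on a different core and does not bear on this change. No measured pair shows what exchanging these two five-membered ring groups does in this assay, and a step that starts from a limit cannot be sized from the numbers shown. Compound 4 is therefore expected to remain near the limit, at an estimated 20000 nM, with a range from 8000 nM to 50000 nM. This estimate means an expected step of a number no higher from compound 3 to compound 4 (the limit leaves the size open), which is not a step beyond the scatter.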

Compound 4, half-maximal inhibitory concentration: > 20000 nM
Compound 4 was reported as a limit; the forecaster's own chance of this, stated with the estimate: 60%; the middle value lies on the limit itself.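

Compound 3 and compound 4 both give a limit rather than a number, so no step between them can be read in this assay: the limit of > 20000 nM in this assay, at which 3 of the 4 values shown sit.

The compounds shown leave open whether thiophen-2-yl in place of 1-benzofuran-2-yl changes the inhibition at all, and how strong either compound really is.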